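This account rests on a few compounds, and the source may have more. Where it says the series, first, only, none or still open, it means among the compounds named here.

Measured so far in a functional assay on MCF7 cells (Homo sapiens) for cytotoxicity, read by MTT assay, with a stated time of 72 h, tested at 30 uM; a lower number here means less inhibition of growth, a higher number more inhibition of growth at the concentration tested:
compound 1 `N/C(=N\NC(=S)N1CCOCC1)c1ccccn1`: 78.1%
compound 2 `N/C(=N\NC(=S)N1CCSCC1)c1ccccn1`: 72.6%

Compound 1 holds the higher of the two numbers, though the step of a number 5.5 percentage points lower from compound 1 to compound 2 (within the scatter) lies within the scatter, so the two are not separated. Compound 3 `N/C(=N\NC(=S)N1CCOCC1)c1ccc(F)cn1` differs from compound 1 by fluoro in place of hydrogen on an aromatic carbon. Going by the values given here, the only measured step, a number 5.5 percentage points lower from compound 1 to compound 2 (within the scatter), exchanges the ring on the thiocarbonyl carbon and does not touch the aromatic carbon, so no measured step bears on this change. No step beyond the scatter is therefore expected in this assay . Compound 3 is estimated at 75%, between 55% and 90%. From compound 1 the step expected is a number 3.1 percentage points lower from compound 1 to compound 3 (within the scatter), within the scatter.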

Compound 3, percent growth inhibition at one concentration: 56.7%
The estimate for compound 3 lay 18.3 percentage points above the measured number, within the range that was stated.
By their numbers in this assay, from the lowest: compound 3; then compounds 2 and 1 (each within the scatter of the next).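

In this assay, fluoro in place of hydrogen on the aromatic carbon two atoms from the ring nitrogen gives a number 21.4 percentage points lower from compound 1 to compound 3 (beyond the scatter). Going by these compounds alone, this is the first step beyond the scatter, so this position of the ring, para to a large group, is sensitive to the addition of a single heavy atom. Nothing measured here bears on why the number falls.

Going by these compounds, whether the loss is specific to fluoro stays open; chloro, methoxy or an amine at this carbon would test that. Also open, on these data alone, is whether the same change on compound 2 gives a similar step.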